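Quinazolinone anilide series: nitrophenyl swap on methylpiperidine core

The source may report more compounds than this note shows. Statements on the series, on what has been measured and on what is new or still open speak of the compounds shown alone.

Compound 1 `COc1cc2c(Oc3ccc(NC(=O)c4nn(-c5ccccc5Br)c(=O)c5ccccc45)cc3F)ccnc2cc1OCCCN1CCCC1` gives 320 nM in a functional assay on NCI-H460 cells (Homo sapiens) for cytotoxicity, read by MTT assay, with a stated time of 72 h; a lower number here means a stronger inhibitor, a higher number a weaker inhibitor. Compound 2 `COc1cc2c(Oc3ccc(NC(=O)c4nn(-c5ccc([N+](=O)[O-])cc5)c(=O)c5ccccc45)cc3F)ccnc2cc1OCCCN1CCCC1` gives 1240 nM in this assay; the step of a 3.9-fold higher number from compound 1 to compound 2 (0.59 log units; beyond the scatter) came from the change (4-nitrophenyl in place of 2-bromophenyl on an aromatic nitrogen). Compound 3 `COc1cc2c(Oc3ccc(NC(=O)c4nn(-c5ccccc5Br)c(=O)c5ccccc45)cc3F)ccnc2cc1OCCCN1CCC(C)CC1` gives 390 nM; the two cores differ as 4-methylpiperidin-1-yl in place of pyrrolidin-1-yl on a saturated chain carbon, three bonds along the chain from an oxygen on an aromatic ring, and the step of a 1.2-fold higher number from compound 1 to compound 3 (0.09 log units; within the scatter) shows the two values within the scatter. Compound 4 `COc1cc2c(Oc3ccc(NC(=O)c4nn(-c5ccc([N+](=O)[O-])cc5)c(=O)c5ccccc45)cc3F)ccnc2cc1OCCCN1CCC(C)CC1` is not yet measured in this assay. It differs from compound 3 by 4-nitrophenyl in place of 2-bromophenyl on an aromatic nitrogen, the same change already seen between compound 1 and compound 2, at a place described in identical words. Since compound 3 matches compound 1 within the scatter, the step is expected to repeat at about its earlier size, a 3.8-fold higher number from compound 3 to compound 4 (0.59 log units; beyond the scatter). Compound 4 is therefore estimated at 1500 nM, between 700 nM and 3500 nM.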

Compound 4, half-maximal inhibitory concentration: 1340 nM
Beside the measured number, compound 4's estimate is 1.1-fold (0.05 log units) above it; low and high end bracket the measured number.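

In this assay, 4-nitrophenyl in place of 2-bromophenyl again gives a step beyond the scatter (a 3.4-fold higher number from compound 3 to compound 4 (0.54 log units; beyond the scatter)), and it carries from the core of compound 1 to the core of compound 3 without a difference beyond the scatter: the same change on two cores in this assay, a 3.9-fold higher number (0.59 log units; beyond the scatter) from compound 1 to compound 2 and a 3.4-fold higher number (0.54 log units; beyond the scatter) from compound 3 to compound 4, 1.1-fold (0.05 log units) apart, within the scatter of two such steps. The change of pyrrolidin-1-yl to 4-methylpiperidin-1-yl also stays within the scatter with 4-nitrophenyl in place (a 1.1-fold higher number from compound 2 to compound 4 (0.03 log units; within the scatter)), matching the earlier step: the same change on two cores in this assay, a 1.2-fold higher number (0.09 log units; within the scatter) from compound 1 to compound 3 and a 1.1-fold higher number (0.03 log units; within the scatter) from compound 2 to compound 4, 1.1-fold (0.05 log units) apart, within the scatter of two such steps. This agreement rests on two cores and one pair of groups, and it does not show that the step holds on any other core.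

Whether the step comes from the bromine, the nitro group or their different ring positions stays open, since 4-bromophenyl and 2-nitrophenyl are not among the compounds shown. Also open, on these data alone, is whether it would persist with a morpholine at the end of the chain.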